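Series notes: sulfur-linked heteroaryl swap on compound 2

A few compounds are considered here, and "the series" means these few. Any claim that something is new, unique, unknown or untested is made for them only; others in the source may bear on it.

Three compounds of the shared core have numbers in a functional assay on C6 cells (Rattus norvegicus) for cytotoxicity, read by MTT assay, with a stated time of 24 h, tested at 200 ug/mL; on this read-out lower numbers stand for a stronger effect and higher numbers for a weaker effect at the one concentration tested. Compound 2 `O=C(CSc1nnnn1-c1ccccc1)N/N=c1/scc(-c2ccc(Cl)cc2)n1-c1ccccc1` gives 52.4%, the highest of the three. Compound 1 `COc1ccc(-c2cs/c(=N/NC(=O)CSc3ncccn3)n2-c2ccccc2)cc1` gives 37.6%, and compound 3 `O=C(CSc1nnnn1-c1ccccc1)N/N=c1/scc(-c2ccc(Br)cc2)n1-c1ccccc1` gives 20.4%. For the measured compounds named here, the only step between two compounds that differ in one place is a number 32 percentage points lower from compound 2 to compound 3 (beyond the scatter), a halogen swap on the aromatic carbon; it tells nothing about the sulfur-linked heteroaryl group.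

Compound 4 `O=C(CSc1ncccn1)N/N=c1/scc(-c2ccc(Cl)cc2)n1-c1ccccc1` is not yet measured. Relative to compound 2 it carries pyrimidin-2-yl in place of 1-phenyl-1H-tetrazol-5-yl on a sulfur. Compound 1 also carries the pyrimidin-2-yl group on the sulfur, but it differs from compound 2 in the aryl group as well, so its value and that of compound 2 do not isolate the change; what the two show is that the pyrimidin-2-yl compound has the lower number of the pair.

Going by the values given here, no measured step bears directly on this change. A step of moderate size toward a lower number is expected, mainly because compound 1 gives 37.6% while compound 2 gives 52.4%, with a wide range around it. For compound 4 the expected value is 42%, with a range from 25% to 60%. The expected step is a number 10.4 percentage points lower from compound 2 to compound 4 (beyond the scatter).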

Compound 4, a percentage reported as activity, at one concentration (the size of the read-out at that concentration, not a potency): 39.7%
The estimate for compound 4 lay 2.3 percentage points above the measured number; the measured number falls inside the stated range.
By their numbers in this assay, from the lowest: compound 3; then compounds 1 and 4 (each within the scatter of the next); then compound 2.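

In this assay, for the compounds shown here, with the chloro aryl group held fixed, pyrimidin-2-yl in place of 1-phenyl-1H-tetrazol-5-yl on a sulfur gives a number 12.7 percentage points lower from compound 2 to compound 4 (beyond the scatter), so the group on the sulfur does move the read-out, which the earlier compounds could not isolate. With pyrimidin-2-yl held on the sulfur, chloro in place of methoxy on an aromatic carbon gives a number 2.1 percentage points higher from compound 1 to compound 4 (within the scatter), so of the two changes separating compound 1 from compound 2, only the swap on the sulfur has a step beyond the scatter. Nothing available explains the step on the sulfur or accounts for the absence of a clear aryl effect.

The compounds shown leave open whether the step on the sulfur follows from the change of heteroaryl ring or from the loss of the phenyl on the tetrazole, a question that a 1-methyl-1H-tetrazol-5-yl or a pyridin-2-yl group on the sulfur would help to separate. They also leave open whether the step seen on going from chloro to bromo with the tetrazole group, a number 32 percentage points lower from compound 2 to compound 3 (beyond the scatter), carries over to compounds with pyrimidin-2-yl on the sulfur.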